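Amide to urea on the anilide arm of compound 2

The compounds below may be only part of what the source reports. "The series", "measured", "known", "first", "only" and "open" are said of these compounds alone.

Going by the values given here, compound 2 `COc1cc(-c2nn(-c3cccc(NC(=O)c4ccc(Cl)c(C(F)(F)F)c4)c3)cc2-c2ccncc2)ccc1Cl` is the one member of the series with a number in a functional assay on Malme-3M cells (Homo sapiens) for inhibition, read by sulforhodamine B assay, with a stated time of 48 h; a higher number here means a weaker inhibitor of growth, a lower number a stronger inhibitor of growth: compound 2 gives 19700 nM. Compound 1 `COc1cc(-c2nn(-c3cccc(NC(=O)c4cccc(C(F)(F)F)c4)c3)cc2-c2ccncc2)ccc1Cl` differs from compound 2 only in a chloro in place of hydrogen on an aromatic carbon. In this assay compound 1 reaches only a limit of the assay, > 50000 nM, as recorded in the limit of > 50000 nM in this assay, at which 1 of the 2 values shown sits. Among the compounds with values here, the step of an at least 2.5-fold lower number from compound 1 to compound 2 (0.40 log units; beyond the scatter) is the single measured step, and one end of it is that limit.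

Compound 3 `COc1cc(-c2nn(-c3cccc(NC(=O)Nc4ccc(Cl)c(C(F)(F)F)c4)c3)cc2-c2ccncc2)ccc1Cl` has not yet been measured. The change is (4-chloro-3-(trifluoromethyl)phenyl)amino in place of 4-chloro-3-(trifluoromethyl)phenyl on a carbonyl carbon. Within the data shown here, no measured step touches the carbonyl carbon or the amide-type nitrogen; the one step known, an at least 2.5-fold lower number from compound 1 to compound 2 (0.40 log units; beyond the scatter), concerns the aromatic ring that stays in place. Among the measured compounds shown here, the series therefore gives no basis for a step of a particular direction. For compound 3 the expected step in this assay is within the scatter, a 1.3-fold lower number from compound 2 to compound 3 (0.12 log units; within the scatter). Compound 3 is estimated at 15000 nM, between 5000 nM and 50000 nM, with a real chance that only a limit is returned.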

Compound 3, concentration for total growth inhibition: 2350 nM
Compound 3: the middle estimate sits 6.4-fold (0.81 log units) above what was measured; measured number outside the range, below it.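

The carbonyl carbon of the anilide arm, untouched by the earlier step, proves to be a position that responds in this assay (with an 8.4-fold lower number from compound 2 to compound 3 (0.92 log units; beyond the scatter)), so the series now moves at a second place as well as on the aromatic ring. The change from amide to urea adds a nitrogen and a hydrogen-bond donor while keeping the 4-chloro-3-(trifluoromethyl)phenyl ring, yet these data cannot say which feature of the entering group carries the gain. Taken from compound 1, which sits at a limit and has no exact number, the combined change with chloro and the added nitrogen is readable only as a bound (with an at least 21-fold lower number from compound 1 to compound 3 (1.32 log units; beyond the scatter)), as its size is capped by the end point: the limit of > 50000 nM in this assay, at which 1 of the 3 values shown sits.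

From the compounds shown here alone, whether the chloro and the urea nitrogen act independently stays open, since a urea bearing 3-(trifluoromethyl)phenyl alone would be needed to separate them. Also open, going by these compounds, is what the nitrogen itself contributes, which could be tested by an N-methyl urea, a carbamate with oxygen at that place, or a methylene linker in place of the nitrogen.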